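The compounds below may be only part of what the source reports. "The series", "measured", "known", "first", "only" and "open" are said of these compounds alone.

Two compounds of this series are in hand. Compound 1 `CSc1nc2cnsc2[nH]1` gives 7000 nM in a functional assay on L1210 cells (Mus musculus) for antiproliferative activity; a lower number here means a stronger inhibitor, a higher number a weaker inhibitor. Compound 2 `Cc1nsc2[nH]c(SCc3ccccc3)nc12` gives 7000 nM in this assay, level with compound 1 at the digits shown, within the scatter. Compound 3 `c1ccc(CSc2nc3cnsc3[nH]2)cc1` is not yet measured. It differs from compound 2 in one place: hydrogen in place of methyl on an aromatic carbon. Within the data shown here, with only two measured compounds, both level, nothing points to an effect of this change either way, and no step beyond the scatter is expected from compound 2 to compound 3 no change at the digits printed from compound 2 to compound 3 (within the scatter). Compound 3 is estimated at 7000 nM, with a range of 3000 nM to 16000 nM.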

Compound 3, half-maximal inhibitory concentration: 300 nM
For compound 3 the middle estimate is 23-fold (1.37 log units) above the measured one; the measured number lies below the stated range.
By their numbers in this assay, from the lowest: compound 3; then compounds 1 and 2 (each within the scatter of the next).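

Hydrogen in place of methyl on this aromatic carbon, next to the ring nitrogen, gives a 23-fold lower number from compound 2 to compound 3 (1.37 log units; beyond the scatter) in this assay. The position is therefore sensitive to substitution, and a single added carbon here is enough to produce a large step, which the earlier level pair gave no sign of. Nothing at hand bears on the reason for this step.

On these data alone, whether fluorine, chlorine, ethyl or an amine on this carbon would read like methyl or like hydrogen stays open. So does whether the step holds with a group other than benzyl on the sulfur.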